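The source may hold more compounds than are shown below. What is called first, only, known or untested is meant among the compounds shown, and "the series" means these compounds.

Measured so far in a functional assay on DLD-1 cells (Homo sapiens) for antiproliferative activity, read by CellTiter-Glo, with a stated time of 72 h; a lower number here means a stronger inhibitor, a higher number a weaker inhibitor:
Compound 1, `Cc1nc(Cl)sc1S(=O)(=O)N1CCC(N2CCC(C)CC2)CC1`: 1.6 nM
Compound 2, `Cc1cc(C)c(S(=O)(=O)N2CCC(C(=O)N3CCC(C)CC3)CC2)c(C)c1`: > 5000 nM, a limit of the assay rather than a number
Compound 3, `Cc1cc(S(=O)(=O)N2CCC(N3CCC(C)CC3)CC2)c(Cl)cc1Cl`: 2 nM

Among the two numbers, compound 1 sits at the strong end, and compound 3 falls within the usual scatter of it, so the two cannot be told apart. Compound 2 sits at the limit of > 5000 nM in this assay, at which 1 of the 3 values shown sits. Compound 4, `CC1CCN(C2CCN(S(=O)(=O)c3ccc(Cl)nc3)CC2)CC1`, has not yet been measured. It differs from compound 1 in one place: 6-chloropyridin-3-yl in place of 2-chloro-4-methyl-1,3-thiazol-5-yl on a sulfonyl sulfur. Among the compounds with values here, no measured pair shows the effect of such a swap, so the expectation rests on compound 1 alone. A small step is expected, a 2.5-fold higher number from compound 1 to compound 4 (0.40 log units; beyond the scatter), within the scatter or slightly toward a weaker inhibitor. Compound 4 is therefore expected to give about 4 nM in this assay, between 1 nM and 15 nM.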

Compound 4, half-maximal inhibitory concentration: 3700 nM
For compound 4 the middle estimate is 930-fold (2.97 log units) below the measured one, outside the stated range (above it).
By their numbers in this assay, from the lowest: compounds 1 and 3 (each within the scatter of the next); then compound 4. At a limit, above all of these: compound 2.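

In this assay, the choice of aromatic ring on the sulfonyl sulfur proves decisive: 6-chloropyridin-3-yl in place of 2-chloro-4-methyl-1,3-thiazol-5-yl gives a 2300-fold higher number from compound 1 to compound 4 (3.36 log units; beyond the scatter), although both groups have the same count of heavy atoms and each carries a chlorine. A single swap at this position can therefore separate a strong inhibitor from a weak one. Nothing measured here explains this large loss.

From the compounds shown here alone, this one swap changes the ring size, the sulfur and the methyl group together, so their separate contributions remain open. Also open, going by these compounds, is whether an amine or a methoxy group in place of the chlorine on the 6-chloropyridin-3-yl ring would recover activity.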